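From Phenol to Isopropyl Ether on a Shared Core

A few compounds are considered here, and "the series" means these few. Any claim that something is new, unique, unknown or untested is made for them only; others in the source may bear on it.

Compound 1, `C=CCOc1ccc(-c2cn3c(=O)n(-c4ccccc4)nc3c(N)n2)cc1`: in an assay on cells for displacement of a labelled ligand from adenosine receptor A1 (Homo sapiens), read by scintillation counting, with a stated time of 3 h (a lower number here means a stronger inhibitor, a higher number a weaker inhibitor), compound 1 has "not determined" (no result reported), so no result is reported for it.
Compound 2, `Nc1nc(-c2ccc(O)cc2)cn2c(=O)n(-c3ccccc3)nc12`: in this assay compound 2 gives 45 nM.
Compound 3, `O=c1[nH]c(-c2ccccc2)cn2c(=O)n(-c3ccccc3)nc12`: in this assay compound 3 reaches only the assay limit, > 30000 nM.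

For the measured compounds named here, compound 2 therefore stands alone as the one compound of the three with a single measured number. Compound 3 sits at the limit of > 30000 nM in this assay, at which 1 of the 3 values shown sits, so its value is a limit and not a number. Compound 1 carries no result at all. Going by the values given here, no step between two measured compounds is available in this set, so nothing about the effect of a change at the oxygen has yet been seen directly.

Compound 4, `CC(C)Oc1ccc(-c2cn3c(=O)n(-c4ccccc4)nc3c(N)n2)cc1`, is the unmeasured partner of compound 2. It differs from compound 2 in one place: isopropyl in place of hydrogen on an oxygen on an aromatic ring. Without a measured step of this kind, the expectation has to be cautious. The step from compound 2 to compound 4 is expected to be small, at most a modest weakening that may not exceed the usual scatter, a 1.6-fold higher number from compound 2 to compound 4 (0.19 log units; within the scatter). Compound 4 is accordingly estimated at 70 nM in this assay, with a plausible range from 15 nM to 300 nM.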

Compound 4, inhibition constant: > 30000 nM
Compound 4 gave a limit, no number (the forecaster's own chance of this, stated with the estimate: 5%); at least 420-fold (2.63 log units) between middle value and limit.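

In this assay, the change from hydroxy to isopropoxy gives an at least 660-fold higher number from compound 2 to compound 4 (2.82 log units; beyond the scatter), the first step seen at this oxygen. It shows that this position is not indifferent to what it carries: with hydrogen on the oxygen the shared core gives a single measured number, and with isopropyl in that place the number is lost. The result for compound 4 is a limit and not a number, so the step shows only a minimum size for this change, and the true size remains unknown: the limit of > 30000 nM in this assay, at which 2 of the 4 values shown sit.

The compounds shown leave open whether a methyl or an ethyl on the same oxygen would keep the binding of compound 2 or lose it as isopropyl does, and so whether the loss needs a branched chain or follows from any alkyl group there. For the compounds shown here, compound 1, with allyl on this oxygen, cannot settle the question, as its entry reads "not determined" (no result reported) and no step to it can be read.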